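Notes on the series: from compound 3 to compound 4

The compounds below may be only part of what the source reports. "The series", "measured", "known", "first", "only" and "open" are said of these compounds alone.

Measured in a functional assay on Jurkat cells (Homo sapiens) for cytotoxicity, read by MTT assay, with a stated time of 24 h; on this read-out lower numbers stand for an effect already at smaller amounts and higher numbers for an effect only at larger amounts of compound:
Compound 1 `CCOC(=O)c1cc([Se]Cc2ccccc2)c2cc(OC)ccc2n1`: 20800 nM
Compound 2 `CCOC(=O)c1cc([Se]c2ccccc2)c2cc(Br)ccc2n1`: 20800 nM
Compound 3 `CCOC(=O)c1cc([Se]Cc2ccccc2)c2cc(Cl)ccc2n1`: 88500 nM

Compound 3 has the highest number of the three, while compound 1 and compound 2 show the same value. The move to compound 4 `CCOC(=O)c1cc([Se]Cc2ccccc2)c2cc(Br)ccc2n1` is bromo in place of chloro on an aromatic carbon. Going by the values given here, the only measured step at this place, chloro in place of methoxy, is a 4.3-fold higher number from compound 1 to compound 3 (0.63 log units; beyond the scatter), modest but beyond the scatter. Among the compounds with values here, no measured step compares bromo with chloro directly. Compound 2 also carries bromo but differs from compound 4 elsewhere. A smaller step towards a lower number is therefore expected in this assay. The expected change is a 2.0-fold lower number from compound 3 to compound 4 (0.29 log units; within the scatter). Compound 4 is estimated at 45000 nM, with an expected range from 17000 nM to 100000 nM.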

Compound 4, half-maximal effective concentration: 53600 nM
For compound 4 the middle estimate is 1.2-fold (0.08 log units) below the measured one, within the range that was stated.
By their numbers in this assay, from the lowest: compounds 1 and 2 (each within the scatter of the next); then compounds 4 and 3 (each within the scatter of the next).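

In this assay, bromo in place of chloro on this aromatic carbon gives a 1.7-fold lower number from compound 3 to compound 4 (0.22 log units; within the scatter), so the two halogens are not told apart here. Bromo in place of methoxy gives a 2.6-fold higher number from compound 1 to compound 4 (0.41 log units; beyond the scatter), which places methoxy apart from both halogens, while benzyl in place of phenyl on a selenium, with bromo kept, gives a 2.6-fold higher number from compound 2 to compound 4 (0.41 log units; beyond the scatter). Nothing measured accounts for these steps.

Still open, going by these compounds, is how an amine or a carboxylic acid would behave on this aromatic carbon. Also open, on these data alone, is whether the benzyl and phenyl step holds with chloro or methoxy in place of bromo.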